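Trading a Benzyl Ether for a Free Hydroxy Group

This account rests on a few compounds, and the source may have more. Where it says the series, first, only, none or still open, it means among the compounds named here.

Measured compounds:
compound 1, `CC1(C)Cc2c(O)ccc(C(=O)/C=C/c3cn(-c4ccccc4)nc3-c3cccc([N+](=O)[O-])c3)c2O1`, gives 25600 nM
compound 2, `CC1(C)Cc2c(OCc3ccccc3)ccc(C(=O)/C=C/c3cn(-c4ccccc4)nc3-c3ccc(Cl)cc3)c2O1`, gives 8400 nM

Both compounds were tested in a functional assay on PC-3 cells (Homo sapiens) for antiproliferative activity, read by MTT assay, with a stated time of 48 h; a higher number here means a weaker inhibitor, a lower number a stronger inhibitor. Compound 2 stands at the lower of the two numbers, and compound 1 sits at a higher number, a gap that lies beyond the usual scatter of this assay. The two compounds differ from each other in more than one place, so this gap cannot be assigned to any single change.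

Compound 3, `CC1(C)Cc2c(O)ccc(C(=O)/C=C/c3cn(-c4ccccc4)nc3-c3ccc(Cl)cc3)c2O1`, is derived from compound 2 by one change: hydrogen in place of benzyl on an oxygen on an aromatic ring. Among the measured pair, the compound carrying the free hydroxy group, compound 1, gives 25600 nM, the weaker result, but its other difference from compound 2 leaves that comparison inconclusive. On that slim basis, a modest loss of potency is expected, a step of a 1.8-fold higher number from compound 2 to compound 3 (0.25 log units; within the scatter), with a real chance that the change stays within the scatter. For compound 3 the expected value in this assay is 15000 nM, with a likely range from 5000 nM to 45000 nM.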

Compound 3, half-maximal inhibitory concentration: 18000 nM
Beside the measured number, compound 3's estimate is 1.2-fold (0.08 log units) below it; low and high end bracket the measured number.
By their numbers in this assay, from the lowest: compound 2; then compounds 3 and 1 (each within the scatter of the next).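

Compound 2 and compound 3 differ only on the oxygen, so the benzyl ether can now be read on its own. In this assay, going from benzyloxy to hydroxy gives a 2.1-fold higher number from compound 2 to compound 3 (0.33 log units; beyond the scatter), a modest step that shows the free hydroxy group is the weaker choice at this position when 4-chlorophenyl is held fixed. Compound 1 and compound 3 both carry the free hydroxy group, and 4-chlorophenyl in place of 3-nitrophenyl gives a 1.4-fold lower number from compound 1 to compound 3 (0.15 log units; within the scatter), so this exchange has no readable effect on the number when the oxygen is uncapped. No measurement shown here accounts for the size of either step.

On these data alone, it remains open whether the aromatic ring of the benzyl group matters, or whether a methyl ether or a longer chain on the same oxygen would give a similar number. As far as these compounds go, it is also open whether the benzyl step would keep its size with 3-nitrophenyl in place of 4-chlorophenyl, or whether a carboxylic acid or an amine on that ring would shift the result.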